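The source may hold more compounds than are shown below. What is called first, only, known or untested is meant among the compounds shown, and "the series" means these compounds.

Values so far in a physicochemical assay for solubility, read by HPLC, at pH 7.4; a lower number here means a less soluble compound, a higher number a more soluble compound:
compound 1 `CCc1c(C)[nH]c2cc(OC)c(F)cc2c1=O` gives < 2000 nM (a limit)
compound 2 `CCc1c(C)[nH]c2cc(OC)c(Cl)cc2c1=O` gives 10000 nM
compound 3 `COc1cc2[nH]c(C)c(C3CCCCC3)c(=O)c2cc1Cl` is not yet measured

The entry for compound 1 is a limit and not a number. Within the data shown here, compound 2 therefore holds the only actual number.

Compound 3 carries cyclohexyl in place of ethyl on an aromatic carbon, ortho to a methyl group (cyclohexyl in place of ethyl on an aromatic carbon), and keeps the chloro of compound 2. Among the measured compounds shown here, the single measured step, an at least 5.0-fold higher number from compound 1 to compound 2 (0.69 log units; beyond the scatter), is chloro in place of fluoro and leaves the ethyl group untouched. It bears only loosely on this change, showing that one change on the shared core can move this assay beyond the scatter. A lower number of similar size is expected here, starting from compound 2 at 10000 nM in this series. The expected step is a 4.0-fold lower number from compound 2 to compound 3 (0.60 log units; beyond the scatter), towards a lower number. For compound 3 the estimate is 2500 nM, with an expected range of 1000 nM to 7000 nM for this read-out.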

Compound 3, solubility: 5000 nM
Compound 3: middle estimate off by 2.0-fold (0.30 log units), on the low side; measured number inside the range.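

In this assay the replacement of ethyl by cyclohexyl on an aromatic carbon, ortho to a methyl group, gives a 2.0-fold lower number from compound 2 to compound 3 (0.30 log units; within the scatter) on the shared core. This position therefore carries cyclohexyl, with 6 heavy atoms and one six-membered non-aromatic ring of carbon only, and the values of the two compounds cannot be told apart in this read-out. Among these compounds, the earlier pair showed only a change of chloro for fluoro and left this position untouched, so this is the first reading of any change here.

Only ethyl and cyclohexyl are shown at this position, so the outcome with an amine or a carboxylic acid there stays open. Whether cyclohexyl behaves the same way with fluoro in place of chloro also stays open, as compound 1 gives a limit and not a number: the limit of < 2000 nM in this assay, at which 1 of the 3 values shown sits.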